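Working notes on the step from compound 2 to compound 3

The source may report more compounds than this note shows. Statements on the series, on what has been measured and on what is new or still open speak of the compounds shown alone.

Two compounds carry numbers in a functional assay on HEK293 cells with D(4) dopamine receptor (Homo sapiens) as the target, read by FLIPR (on this read-out lower numbers stand for an effect already at smaller amounts and higher numbers for an effect only at larger amounts of compound), so far. Compound 1 `O/N=C(/CCN1CCN(c2ccccn2)CC1)c1ccccc1Cl` gives 25 nM, and compound 2 `CCO/N=C(\CCN1CCN(c2ccccc2C#N)CC1)c1ccccc1` gives 48.7 nM. Compound 2 holds the higher of the two numbers, yet the gap to compound 1 lies within the scatter, so the two read as alike on this assay.

Compound 3 `CCO/N=C(\CCN1CCN(c2ccc(OC)cc2)CC1)c1ccccc1` has not been measured. It differs from compound 2 in one place: 4-methoxyphenyl in place of 2-cyanophenyl on an amine nitrogen in a ring, in words 4-methoxyphenyl in place of 2-cyanophenyl on an amine nitrogen in a ring. Going by the values given here, no measured pair shows this change, so there is no step to lean on; the two measured compounds, which differ from each other in several places, sit close together.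

The expected step of a 1.2-fold higher number from compound 2 to compound 3 (0.09 log units; within the scatter) is none beyond the scatter, in either direction. The estimate for compound 3 in this assay is 60 nM, with a range from 15 nM to 250 nM.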

Compound 3, half-maximal effective concentration: > 10000 nM
Compound 3 ended at the assay's limit (the forecaster's own chance of this, stated with the estimate: 5%); middle value at least 160-fold (2.22 log units) from the limit.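

In this assay, 4-methoxyphenyl in place of 2-cyanophenyl on an amine nitrogen in a ring gives an at least 200-fold higher number from compound 2 to compound 3 (2.31 log units; beyond the scatter), so this position can decide whether the series reads in this assay at all, which compound 1 and compound 2, differing in several places and lying within the scatter of each other, gave no sign of. Compound 3 gives > 10000 nM, which is a limit and not a number, so the step has a lower bound only: the limit of > 10000 nM in this assay, at which 1 of the 3 values shown sits. The two groups match in heavy-atom count, in one six-membered aromatic ring of carbon only and in hydrogen-bond acceptor count, so these counts do not separate compound 2 from compound 3.

Open, going by these compounds, is whether the step follows the nitrile leaving, the methoxy entering or the place of the substituent on the aryl ring. Plain phenyl, 2-methoxyphenyl and 4-cyanophenyl on that nitrogen would separate these readings.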